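The source may report more compounds than this note shows. Statements on the series, on what has been measured and on what is new or still open speak of the compounds shown alone.

Measured compounds:
- compound 1 `OC(c1ccc(Cl)cc1)(c1cccnc1)c1ccc(Cl)cc1F`: 59400 nM
- compound 2 `OC(c1ccc(Cl)cc1)(c1cccnc1)c1ccc(C(F)(F)F)cc1F`: 57400 nM
- compound 3 `CC(C)Oc1ccc(C(O)(c2ccc(Cl)cc2)c2cccnc2)c(F)c1`: 58200 nM

In an ADME assay on L6 cells (Rattus norvegicus) for cytotoxicity, read by resazurin assay, with a stated time of 72 h (a lower number here means a stronger inhibitor, a higher number a weaker inhibitor), these three compounds lie within the scatter of one another, so compound 1 holds no distinct rank among them. Compound 4 `CC(C)Oc1ccc(C(O)(c2cccnc2)c2ccc(Cl)cc2F)cc1` departs from compound 1 by isopropoxy in place of chloro on an aromatic carbon. The closest evidence is a 1.0-fold lower number from compound 1 to compound 3 (0.01 log units; within the scatter), the same kind of exchange, although the chloro replaced there is not the one replaced here. The other two steps, a 1.0-fold lower number from compound 1 to compound 2 (0.01 log units; within the scatter) and a 1.0-fold higher number from compound 2 to compound 3 (0.01 log units; within the scatter), are equally small and also within the scatter. No step beyond the scatter is therefore expected, and the estimated step is a 1.0-fold lower number from compound 1 to compound 4 (0.02 log units; within the scatter). For compound 4 the estimated value is 57000 nM, with an expected range from 32000 nM to 95000 nM.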

Compound 4, half-maximal inhibitory concentration in the L6 assay: 56000 nM
For compound 4 the middle estimate is 1.0-fold (0.01 log units) above the measured one; the range from low to high includes it.
By their numbers in the L6 assay, from the lowest: compounds 4, 2, 3 and 1 (each within the scatter of the next).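

Among the compounds shown here, exchanging the second chloro of compound 1 for isopropoxy, at the carbon para to a large group, leaves the L6 assay within the scatter (a 1.1-fold lower number from compound 1 to compound 4 (0.03 log units; within the scatter)), so the chloro replaced in compound 3 is not the only one open to this exchange. In a physicochemical assay for solubility, read by nephelometry, measured as kinetic solubility, at pH 6.5 (on this read-out lower numbers stand for lower solubility and higher numbers for higher solubility), the same exchange gives the result (no change at the digits printed from compound 1 to compound 4 (within the scatter)), with compound 1 at (1.6 ug/mL) and compound 4 at (1.6 ug/mL), so this read-out also separates neither compound. Nothing available explains either result. From the compounds shown here alone, whether an amine or a carboxylic acid at this carbon would move either read-out remains open, as does the effect of a longer alkoxy chain.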